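The compounds below may be only part of what the source reports. "The series", "measured", "known", "first", "only" and "open" are said of these compounds alone.

Compound 1 `CC(=O)Nc1ccc2nc(SCC(=O)NCc3ccccc3)sc2c1`: in a functional assay on MCF7 cells (Homo sapiens) for cytotoxicity, read by MTT assay, with a stated time of 48 h (on this read-out higher numbers stand for weaker inhibition and lower numbers for stronger inhibition), compound 1 gives 17600 nM.
Compound 2 `CNC(=O)CSc1nc2ccc(NC(=O)c3ccc([N+](=O)[O-])cc3)cc2s1`: in this assay compound 2 gives only a limit, > 100000 nM.

Compound 2 thus sits at the limit of > 100000 nM in this assay, at which 1 of the 2 values shown sits, a limit of the assay and not a number. Compound 3 `O=C(CSc1nc2ccc(NC(=O)c3ccc([N+](=O)[O-])cc3)cc2s1)NCc1ccccc1` differs from compound 2 by phenyl in place of hydrogen on a saturated chain carbon bound to an amide-type nitrogen. Going by the values given here, no measured pair shows this change on its own, so any expectation is loose: compound 3 is expected to move toward stronger inhibition by an estimated at least 2.0-fold lower number from compound 2 to compound 3 (0.30 log units; that floor lies within the scatter), with wide uncertainty. Compound 3 is therefore expected at 50000 nM, between 15000 nM and 200000 nM.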

Compound 3, half-maximal inhibitory concentration: > 100000 nM
Compound 3 gave a limit, no number; the forecaster's own chance of this, stated with the estimate: 45%; at least 2.0-fold (0.30 log units) between middle value and limit.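

With the benzylcarbamoyl group kept, 4-nitrophenyl in place of methyl on a carbonyl carbon brings an at least 5.6-fold higher number from compound 1 to compound 3 (0.75 log units; beyond the scatter) in this assay. Phenyl in place of hydrogen on a saturated chain carbon bound to an amide-type nitrogen does not bring a readable number while 4-nitrophenyl stays. That step cannot be read, since compound 2 and compound 3 each give a limit of the assay and not a number: the limit of > 100000 nM in this assay, at which 2 of the 3 values shown sit.

Still open, going by these compounds, is whether the nitro group or the phenyl ring accounts for the step. A plain phenyl or a 4-aminophenyl group on that carbonyl carbon would speak to this.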